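Fluoro to Chloro: Expecting Only a Small Step

This account rests on a few compounds, and the source may have more. Where it says the series, first, only, none or still open, it means among the compounds named here.

In an assay on a cell-free system (plasma) for inhibition of proteinase-activated receptor 1 (Homo sapiens), read by flow cytometry, with a stated time of 20 min (a lower number here means a stronger inhibitor, a higher number a weaker inhibitor), compound 1 `CCCC(=O)Nc1cccc(NC(=O)c2cc(C)ccc2Br)c1` gives 480 nM. Among the measured compounds shown here, compound 2 `CCCC(=O)Nc1cccc(NC(=O)c2cc(F)ccc2Br)c1`, with fluoro in place of methyl on an aromatic carbon, gives 600 nM in this assay; with only two numbers measured, the step of a 1.3-fold higher number from compound 1 to compound 2 (0.10 log units; within the scatter) lies within the scatter, so compound 2 stands level with compound 1. Compound 3 `CCCC(=O)Nc1cccc(NC(=O)c2cc(Cl)ccc2Br)c1` differs from compound 2 by chloro in place of fluoro on an aromatic carbon. For the measured compounds named here, the one measured step at this position, a 1.3-fold higher number from compound 1 to compound 2 (0.10 log units; within the scatter), was small, so no change beyond the scatter is expected, that is a 1.2-fold lower number from compound 2 to compound 3 (0.06 log units; within the scatter). Compound 3 is therefore estimated at 520 nM, within 250 nM to 1100 nM.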

Compound 3, half-maximal inhibitory concentration: 380 nM
The estimate for compound 3 lay 1.4-fold (0.14 log units) above the measured number, and the stated range covers the measured number.
By their numbers in this assay, from the lowest: compounds 3, 1 and 2 (each within the scatter of the next).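

Chloro now joins fluoro and methyl at this position, para to a bromo group, and in this assay the three stand level: chloro in place of fluoro is a 1.6-fold lower number from compound 2 to compound 3 (0.20 log units; within the scatter) and chloro in place of methyl is a 1.3-fold lower number from compound 1 to compound 3 (0.10 log units; within the scatter). Across these three groups, no step at this position goes beyond the scatter. No measured evidence here accounts for this result. Still open, as far as these compounds go, is whether an amine, a carboxylic acid or a longer chain at this same position would also stand level with these three or would move the number beyond the scatter.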